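The compounds below may be only part of what the source reports. "The series", "measured", "known", "first", "only" and "open" are said of these compounds alone.

Measured in a functional assay on Jurkat cells (Homo sapiens) for antiproliferative activity, read by MTT assay; on this read-out higher numbers stand for weaker inhibition and lower numbers for stronger inhibition:
Compound 1, `COc1cccc(/C=C2\CCc3cc(OC)c(OC)cc3C2=O)c1`, gave 5000 nM.
Compound 2, `COc1cc2c(cc1OC)C(=O)/C(=C/c1cccc(Cl)c1)CC2`, gave 9000 nM.
Compound 3, `COc1cc2c(cc1OC)C(=O)/C(=C/c1cccc(Cl)c1)C2`, gave 8000 nM.

All three compounds carry the same two methoxy groups on their core and a substituted phenyl ring joined to that core through a double bond. Compound 1 and compound 2 share one core; compound 3 has a related but smaller core, and how the cores of compound 3 and compound 2 differ is not broken down here. The values of compound 3 and compound 2 lie within the scatter of each other, as do those of compound 3 and compound 1.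

One change has been measured directly: going from compound 2 to compound 1 means (methoxy in place of chloro on an aromatic carbon), and this gave a 1.8-fold lower number from compound 2 to compound 1 (0.26 log units; within the scatter), a shift that the scatter of the measurement can account for on its own.

Compound 4, `COc1cccc(/C=C2\Cc3cc(OC)c(OC)cc3C2=O)c1`, is not yet measured. It has the core of compound 3 and differs from compound 3 by methoxy in place of chloro on an aromatic carbon. The surroundings of the change are described in the same words as for the pair of compound 2 and compound 1, so it is the same change made on a different core.

For compound 4, a step of about a 1.8-fold lower number from compound 3 to compound 4 (0.25 log units; within the scatter) is expected, because the identical change on the other core gave a 1.8-fold lower number from compound 2 to compound 1 (0.26 log units; within the scatter). Starting from compound 3, compound 4 is therefore estimated at 4500 nM, with a likely range from 2000 nM to 10000 nM.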

Compound 4, half-maximal inhibitory concentration: 12800 nM
Estimate against measurement, compound 4: 2.8-fold (0.45 log units) below, and the stated range ends below it.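

In this assay, putting methoxy in place of chloro on an aromatic carbon of the core of compound 3 gave a 1.6-fold higher number from compound 3 to compound 4 (0.20 log units; within the scatter), a step that on its own is small. Set beside the earlier step on the other core, however, the same change did not carry over as a fixed shift from one core to the other, so a step measured on one of these cores is a poor guide to the step on the other: the same change on two cores in this assay, a 1.8-fold lower number (0.26 log units; within the scatter) from compound 2 to compound 1 and a 1.6-fold higher number (0.20 log units; within the scatter) from compound 3 to compound 4, 2.9-fold (0.46 log units) apart, beyond the scatter of two such steps. This comparison rests on a single pair of compounds on each core, and each step alone lies within the scatter, so it does not show which of the two steps is the more reliable, why the cores differ, or that the same would hold for any other swap of groups.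

The compounds shown carry either chloro or methoxy on the phenyl ring and sit on just these two cores, so it remains open whether the gap between the cores would recur with a hydroxy group, an amine or a carboxylic acid at that place. From the compounds shown here alone, it also remains open whether a group of this kind would give steps large enough to stand clear of the scatter on each core separately.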